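This account rests on a few compounds, and the source may have more. Where it says the series, first, only, none or still open, it means among the compounds named here.

In a functional assay on Jurkat cells for inhibition of nuclear factor NF-kappa-B complex (Homo sapiens) (on this read-out lower numbers stand for stronger inhibition and higher numbers for weaker inhibition), the two compounds measured share a common core carrying an ethoxycarbonyl group and a substituted aryl ring. Compound 1 `CCOC(=O)c1cnc(-c2cccc(OC)c2)nc1NN1C(=O)C=C(C)C1=O` gives 5000 nM, while compound 2 `CCOC(=O)c1cnc(-c2ccc(F)cc2)nc1NN1C(=O)C=C(C)C1=O` gives 700 nM. Compound 2 thus stands at the lowest of the two numbers, and its nearest neighbour is compound 1, separated by a 7.1-fold lower number from compound 1 to compound 2 (0.85 log units; beyond the scatter). Compound 3 `CCOC(=O)c1cnc(-c2ccc(C)s2)nc1NN1C(=O)C=C(C)C1=O` differs from compound 2 only at that same aryl ring: 5-methylthiophen-2-yl in place of 4-fluorophenyl on an aromatic carbon. Among the measured compounds shown here, the one step that bears on this exchange is the ring swap from compound 1 to compound 2, which gave a 7.1-fold lower number from compound 1 to compound 2 (0.85 log units; beyond the scatter), a modest shift, so a replacement of the aryl ring at this position is known to move this assay by a modest amount, in either direction. With nothing showing where a five-membered ring falls, compound 3 is expected to sit near compound 2, with a step of a 1.7-fold higher number from compound 2 to compound 3 (0.23 log units; within the scatter), estimated at 1200 nM, in a range from 250 nM to 6000 nM.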

Compound 3, half-maximal inhibitory concentration: 200 nM
The estimate for compound 3 lay 6.0-fold (0.78 log units) above the measured number, and the stated range ends above it.
By their numbers in this assay, from the lowest: compound 3; then compound 2; then compound 1.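

In this assay, a five-membered ring is now shown to work at this position, on an aromatic carbon between two ring nitrogen atoms: putting 5-methylthiophen-2-yl in place of 4-fluorophenyl gives a 3.5-fold lower number from compound 2 to compound 3 (0.54 log units; beyond the scatter). Set against the 3-methoxyphenyl group, the same ring gives a 25-fold lower number from compound 1 to compound 3 (1.40 log units; beyond the scatter), so the choice of aryl group here spans a wider range than the first pair showed, and the six-membered rings are not the best of the three groups. Nothing at hand explains this order.

As far as these compounds go, whether the lower number goes with the sulfur-containing ring or with its methyl group stays open, and a plain thiophen-2-yl group would separate the two. Also open, from the compounds shown here alone, is how a pyridine ring, or a ring bearing an amine or a carboxylic acid, would fall at this position.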